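Trifluoromethyl enters: what to expect for compound 3

The source may hold more compounds than are shown below. What is called first, only, known or untested is meant among the compounds shown, and "the series" means these compounds.

- compound 1 `CC(O)(CSc1ccc(F)cc1)C(=O)Nc1ccc(S(F)(F)(F)(F)F)cc1` gives 12500 nM
- compound 2 `CC(O)(COc1ccc(S(F)(F)(F)(F)F)cc1)C(=O)Nc1cccc(S(F)(F)(F)(F)F)c1` gives 8000 nM

Both numbers come from a functional assay on LNCaP cells (Homo sapiens) for antiproliferative activity, read by propidium iodide staining, with a stated time of 96 h (on this read-out higher numbers stand for weaker inhibition and lower numbers for stronger inhibition), and they lie within the usual scatter of each other. On this evidence, compound 2 stands level with compound 1. Among the measured compounds shown here, the two compounds differ in more than one place, so no measured step shows what one change alone does.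

Compound 3 `CC(O)(COc1ccc(C(F)(F)F)cc1)C(=O)Nc1cccc(S(F)(F)(F)(F)F)c1` still awaits measurement in this assay and differs from compound 2 in one place: a group of 4 heavy atoms (1 carbon, 3 fluorine; no ring) in place of a group of 6 heavy atoms (5 fluorine, 1 sulfur; no ring), on an aromatic carbon. The change sits on an aromatic carbon of a six-membered aromatic ring of carbon only, para to a large group, and the group that enters is trifluoromethyl.

For the measured compounds named here, the only close reference is compound 2 at 8000 nM, so the estimate starts from that value. No shift beyond the scatter is expected, though a slightly higher number, meaning slightly weaker inhibition, seems a little more likely than a lower one. The expected size of the change is a 1.3-fold higher number from compound 2 to compound 3 (0.10 log units; within the scatter), which stays within the scatter. For compound 3 the estimated value is 10000 nM, with an expected range from 3500 nM to 25000 nM.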

Compound 3, half-maximal inhibitory concentration: 9600 nM
For compound 3 the middle estimate is 1.0-fold (0.02 log units) above the measured one; the range from low to high includes it.
By their numbers in this assay, from the lowest: compounds 2, 3 and 1 (each within the scatter of the next).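

In this assay the exchange on this aromatic carbon, with trifluoromethyl entering in place of the group of 6 heavy atoms (5 fluorine, 1 sulfur), amounts to a 1.2-fold higher number from compound 2 to compound 3 (0.08 log units; within the scatter) and gives the series its first comparison of compounds that differ in one place. At this position, para to a large group, the two groups cannot be told apart on this read-out, so the smaller group of 4 heavy atoms leaves the number within the scatter of the larger one. Nothing measured here accounts for this close match.

Among the compounds shown here, this single step covers only two fluorine-bearing groups at one position, so it remains open whether an amine, a carboxylic acid, a nitrile or a longer chain on the same aromatic carbon would move the number beyond the scatter. On these data alone, it also remains open whether trifluoromethyl would give a similar result in place of the group of 6 heavy atoms that compound 3 still carries elsewhere in the molecule.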